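This account rests on a few compounds, and the source may have more. Where it says the series, first, only, none or still open, it means among the compounds named here.

Among the measured compounds shown here, compound 1 `O=C(Nc1cccc(-c2oc3cc(-c4ccc(F)cc4)ccc3c(=O)c2O)c1)c1ccc(F)cc1` gives 8590 nM in a functional assay on MCF7 cells (Homo sapiens) for antiproliferative activity, read by CCK-8 assay, with a stated time of 72 h (a higher number here means a weaker inhibitor, a lower number a stronger inhibitor), the highest of the two numbers measured so far. For the measured compounds named here, its only measured neighbour is compound 2 `O=C(Nc1cccc(-c2oc3cc(-c4ccc(F)cc4)ccc3c(=O)c2O)c1)c1cccc(F)c1`, which in this assay gives 5770 nM; the single recorded step, a 1.5-fold lower number from compound 1 to compound 2 (0.17 log units; within the scatter), stays within the scatter. Compound 3 `O=C(Nc1cccc(-c2oc3cc(-c4ccc(F)cc4)ccc3c(=O)c2O)c1)c1ccc(-c2ccccc2)cc1` differs from compound 1 in one place: phenyl in place of fluoro on an aromatic carbon. Going by the values given here, no measured step touches this change; the replacement of fluoro by phenyl on that aromatic carbon has no precedent among the measured compounds. Among the compounds with values here, the one known step concerns a different part of the molecule and is itself within the scatter, so it offers no direction. With nothing to argue for a large movement either way, compound 3 is expected to move little, an expected step of a 1.4-fold lower number from compound 1 to compound 3 (0.16 log units; within the scatter). The estimate for compound 3 in this assay is 6000 nM, within a range from 1500 nM to 25000 nM.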

Compound 3, half-maximal inhibitory concentration: 38500 nM
For compound 3 the middle estimate is 6.4-fold (0.81 log units) below the measured one; the whole stated range lies below it.
By their numbers in this assay, from the lowest: compounds 2 and 1 (each within the scatter of the next); then compound 3.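

In this assay, among the compounds shown here, phenyl in place of fluoro on this aromatic carbon gives a 4.5-fold higher number from compound 1 to compound 3 (0.65 log units; beyond the scatter), the first step beyond the scatter and the first sign that this position, para to a large group, responds to what is placed on it. The step 4-phenylphenyl in place of 3-fluorophenyl, which gives a 6.7-fold higher number from compound 2 to compound 3 (0.82 log units; beyond the scatter), points the same way, so among these three compounds only the 4-phenylphenyl amide stands apart as a weaker inhibitor. No measurement at hand says why the number rises.

The compounds shown leave open whether the rise is specific to a second phenyl ring or would also appear with a methyl, a methoxy or an amine on that carbon. They also leave open whether a carboxylic acid on the added phenyl ring would shift the number in either direction.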